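The source may report more compounds than this note shows. Statements on the series, on what has been measured and on what is new or still open speak of the compounds shown alone.

Compound 1 `O=CN1CCN(c2ccc(Cl)cc2)C1=S`: 23000 nM in a functional assay on NCI-H23 cells (Homo sapiens) for inhibition, read by sulforhodamine B assay, with a stated time of 48 h; a higher number here means a weaker inhibitor of growth, a lower number a stronger inhibitor of growth
Compound 2 `N#C/C(=C\N1CCN(C(=O)c2ccco2)C1=S)C(N)=O`: 21400 nM
Compound 3 `COc1cc(C(=O)N2CCN(C=O)C2=S)cc(OC)c1OC`: 25900 nM

The three measured compounds share one core and were all read in this assay after the same exposure. Their numbers lie close together. Compound 2 sits at the low end of the three, yet compound 1 is its nearest neighbour and compound 3 its furthest, and both of them fall within the usual scatter of compound 2, so the three compounds cannot be told apart on these data and no order among them is claimed.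

Compound 4 `N#C/C(=C\N1CCN(C(=O)c2ccco2)C1=S)C(=O)c1ccccc1` keeps the core of compound 2 and its furan-bearing amide, and differs from it in one place: phenyl in place of amino on a carbonyl carbon. Cut one bond further out, the same change reads as carbamoyl to benzoyl. Among the compounds with values here, no measured pair in the set carries this change, so nothing in the data sets its size or direction. Given how tightly compounds 1, 2 and 3 cluster in this assay, the expectation is a step from compound 2 to compound 4 of a 1.1-fold lower number from compound 2 to compound 4 (0.03 log units; within the scatter), that is none beyond the scatter. Compound 4 is therefore expected to give about 20000 nM in this assay, within a range from 7000 nM to 55000 nM.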

Compound 4, concentration for 50% growth inhibition: 15200 nM
Beside the measured number, compound 4's estimate is 1.3-fold (0.12 log units) above it; the measured number falls inside the stated range.
By their numbers in this assay, from the lowest: compounds 4, 2, 1 and 3 (each within the scatter of the next).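

On the carbonyl carbon whose other neighbour is the double-bonded chain carbon, phenyl in place of amino gives (a 1.4-fold lower number from compound 2 to compound 4 (0.15 log units; within the scatter)) in this assay and stays within the scatter. Within the data shown here, the earlier compounds offered no pair differing in one place, so this is the first step that can be read in the set, and it shows that this carbonyl carbon can carry a six-membered aromatic ring of carbon only, with six heavy atoms instead of one and without the hydrogen-bond donor of the amino group, while compound 4 remains indistinguishable from compound 2 in this read-out. No measurement shown here speaks to why the carbamoyl to benzoyl change leaves the number within the scatter.

On these data alone, it remains open whether a methyl, a methoxy or a dimethylamino group on the same carbonyl carbon, or a phenyl ring bearing a chlorine or a carboxylic acid, would move the number beyond the scatter. Also open, as far as these compounds go, is whether the same change would read alike with a thiophene-bearing amide in place of the furan-bearing amide on the shared core.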